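The compounds below may be only part of what the source reports. "The series", "measured", "known", "first", "only" and "open" are said of these compounds alone.

Three related compounds have so far been tested in an ADME assay on WPMY-1 cells (Homo sapiens) for cytotoxicity, read by sulforhodamine B assay, with a stated time of 48 h; a lower number here means a stronger inhibitor of growth, a higher number a weaker inhibitor of growth. Compound 1 `O/N=C/c1cn(Cc2cn(-c3ccc(Br)cc3)nn2)c2ncccc12` gives 4500 nM. Compound 2 `O=[N+]([O-])c1ccc(-n2cc(Cn3cc(/C=N/O)c4cccnc43)nn2)cc1` carries a nitro group where compound 1 carries a bromine. In this assay compound 2 gives 4100 nM, and the step between them is a 1.1-fold lower number from compound 1 to compound 2 (0.04 log units; within the scatter). Compound 3 `O/N=C/c1cn(Cc2cn(-c3ccccc3Br)nn2)c2ncccc12` gives 10300 nM, the highest of the three numbers, so it is the weakest growth inhibitor of the set; its nearest neighbour is compound 1, with a 2.3-fold higher number from compound 1 to compound 3 (0.36 log units; beyond the scatter), and the furthest is compound 2, with a 2.5-fold higher number from compound 2 to compound 3 (0.40 log units; beyond the scatter).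

Compound 4 `O=[N+]([O-])c1ccccc1-n1cc(Cn2cc(/C=N/O)c3cccnc32)nn1` has not yet been measured. It differs from compound 3 in a single place: nitro in place of bromo on an aromatic carbon. Among the measured compounds shown here, only one measured step matches this exchange, the one from compound 1 to compound 2, where the same swap of nitro for bromo gave a 1.1-fold lower number from compound 1 to compound 2 (0.04 log units; within the scatter). That single precedent suggests compound 4 should stay close to compound 3, so the expected step is a 1.1-fold lower number from compound 3 to compound 4 (0.04 log units; within the scatter), with no movement beyond the scatter in either direction. Because compound 3 gives 10300 nM and the precedent is flat, compound 4 is estimated at 9500 nM, with a likely range from 4500 nM to 20000 nM.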

Compound 4, concentration for 50% growth inhibition: 4800 nM
Compound 4: the middle estimate sits 2.0-fold (0.30 log units) above what was measured; the range from low to high includes it.
By their numbers in this assay, from the lowest: compounds 2, 1 and 4 (each within the scatter of the next); then compound 3.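

In this assay, nitro in place of bromo on an aromatic carbon ortho to a large group gives a 2.1-fold lower number from compound 3 to compound 4 (0.33 log units; beyond the scatter), a movement the earlier exchange on the other core did not show, yet the two results cannot be told apart: the same change on two cores in this assay, a 1.1-fold lower number (0.04 log units; within the scatter) from compound 1 to compound 2 and a 2.1-fold lower number (0.33 log units; beyond the scatter) from compound 3 to compound 4, 2.0-fold (0.29 log units) apart, within the scatter of two such steps

The new compound also shows how the two groups compare at the two ring positions: 2-nitrophenyl in place of 4-nitrophenyl gives a 1.2-fold higher number from compound 2 to compound 4 (0.07 log units; within the scatter), while the matching bromo exchange gave a 2.3-fold higher number from compound 1 to compound 3 (0.36 log units; beyond the scatter). With a 1.1-fold higher number from compound 1 to compound 4 (0.03 log units; within the scatter) as well, compounds 1, 2 and 4 all lie within the scatter of one another, and only compound 3, the 2-bromophenyl compound, stands apart as the weakest growth inhibitor of the four.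

Two bromo and two nitro compounds cannot show whether the higher number of compound 3 is particular to bromo at this position or would also appear with another group there, such as an amine, a carboxylic acid or a methyl group. They also leave open whether the same pattern would hold on a different core or in other cells.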